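Furan-2-yl for 1,3-thiazol-5-yl among limits

The source may hold more compounds than are shown below. What is called first, only, known or untested is meant among the compounds shown, and "the series" means these compounds.

Measured in a physicochemical assay for solubility, read by HPLC, with a stated time of 24 h (on this read-out higher numbers stand for higher solubility and lower numbers for lower solubility), on the shared core, each entry a limit and not a number:
- compound 1 (`CC(C)(C)c1[nH]cnc1/C=c1\[nH]c(=O)/c(=C/c2cccc(C(=O)c3ccccc3)c2)[nH]c1=O`) gives < 0.1 ug/mL as a limit
- compound 2 (`CC(C)(C)c1[nH]cnc1/C=c1\[nH]c(=O)/c(=C/c2cccc(C(=O)c3cccs3)c2)[nH]c1=O`) gives < 0.1 ug/mL as a limit
- compound 3 (`CC(C)(C)c1[nH]cnc1/C=c1\[nH]c(=O)/c(=C/c2cccc(C(=O)c3cncs3)c2)[nH]c1=O`) gives < 0.1 ug/mL as a limit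

Compound 3 stands at < 0.1 ug/mL as a limit, so its place is known only as a bound. Within the data shown here, the series so far offers nothing else (the limit of < 0.1 ug/mL in this assay, at which 3 of the 3 values shown sit).

The next structure is compound 4 (`CC(C)(C)c1[nH]cnc1/C=c1\[nH]c(=O)/c(=C/c2cccc(C(=O)c3ccco3)c2)[nH]c1=O`), which carries furan-2-yl in place of 1,3-thiazol-5-yl on a carbonyl carbon. The measured steps at that same place are a step that the two limits leave unreadable from compound 1 to compound 2 and a step that the two limits leave unreadable from compound 1 to compound 3 and also a step that the two limits leave unreadable from compound 2 to compound 3 and so none of them offers a size to carry over.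

No step beyond the usual scatter can be founded on them, so none is expected in this assay and no direction is foreseen. That expectation rests chiefly on the limit of compound 3 at < 0.1 ug/mL and on the absence of any readable number nearby. The estimated change is a step that the limit leaves unreadable from compound 3 to compound 4 and it should not be read as a real shift. For compound 4 the estimated value is 0.07 ug/mL within an expected range from 0.03 ug/mL to 0.2 ug/mL and in all likelihood it is expected to stand as a limit only.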

Compound 4, solubility: < 0.1 ug/mL
Compound 4 ended at the assay's limit; the forecaster's own chance of this, stated with the estimate: 80%; the middle value is on the limit's open side.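

In this assay compound 4 gives < 0.1 ug/mL as a limit. Among these compounds, no step can therefore be read from compound 1, compound 2 or compound 3 to compound 4, since all four entries are bounds: the limit of < 0.1 ug/mL in this assay, at which 4 of the 4 values shown sit. The compounds shown leave open whether phenyl, thiophen-2-yl, 1,3-thiazol-5-yl and furan-2-yl on the carbonyl carbon differ at all in this assay.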